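Pyrazole attachment swapped on two urea cores: compound 4

This account rests on a few compounds, and the source may have more. Where it says the series, first, only, none or still open, it means among the compounds named here.

The first pair shares one core: compound 1 `CSc1cc(C)nc(SC)c1NC(=O)N(Cc1ccccc1)Cc1cccc(-c2ccn(C)n2)c1` and compound 2 `CSc1cc(C)nc(SC)c1NC(=O)N(Cc1ccccc1)Cc1cccc(-c2ccnn2C)c1`. In a functional assay on a cell-free system (plasma) with sterol O-acyltransferase, Soat (Rattus norvegicus) as the target (on this read-out lower numbers stand for an effect already at smaller amounts and higher numbers for an effect only at larger amounts of compound), compound 1 gives only a limit of the assay, < 1 mg/kg. In this assay compound 2 likewise gives only a limit, < 1 mg/kg. The change between them is 1-methyl-1H-pyrazol-5-yl in place of 1-methyl-1H-pyrazol-3-yl on an aromatic carbon and the step it made, a step that the two limits leave unreadable from compound 1 to compound 2, cannot be read because both values sit at the limit of < 1 mg/kg in this assay, at which 3 of the 3 values shown sit.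

Compound 3 `Cc1cc(C)c(NC(=O)N(Cc2cccc(-c3ccn(C)n3)c2)C2CCCCCC2)c(C)c1` has a different core; the difference between the two cores is not broken down here. In this assay compound 3 also gives only a limit, < 1 mg/kg.

Compound 4 `Cc1cc(C)c(NC(=O)N(Cc2cccc(-c3ccnn3C)c2)C2CCCCCC2)c(C)c1` has not yet been measured in this assay. It carries the same change on the core of compound 3 that compound 2 carries on the core of compound 1: 1-methyl-1H-pyrazol-5-yl in place of 1-methyl-1H-pyrazol-3-yl on an aromatic carbon. Since the earlier step is unreadable and all three values shown rest at the limit of < 1 mg/kg in this assay, at which 3 of the 3 values shown sit, the step expected from compound 3 to compound 4 is a step that the limit leaves unreadable from compound 3 to compound 4, essentially no shift. Compound 4 is therefore estimated in this assay at 0.5 mg/kg, between 0.1 mg/kg and 1.5 mg/kg.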

Compound 4, dose for half-maximal effect: > 1 mg/kg
Compound 4 gave a limit, no number; the forecaster's own chance of this, stated with the estimate: 80%; at least 2.0-fold (0.30 log units) between middle value and limit.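

On the core of compound 3, 1-methyl-1H-pyrazol-5-yl in place of 1-methyl-1H-pyrazol-3-yl gave a number no lower from compound 3 to compound 4 (the limit leaves the size open) in this assay, so on this core the change shows a direction but no size. Compound 4 gives > 1 mg/kg, which is a limit of the assay and not a number. On the core of compound 1 the same change cannot be read, so the compounds shown do not say whether it carries over from one core to the other or acts differently on each: the limit of < 1 mg/kg in this assay, at which 3 of the 4 values shown sit.

The compounds shown leave open how large the step on the core of compound 3 really is, and whether a step of any size lies hidden on the core of compound 1. They also leave open how an amine or a carboxylic acid would read in this assay if carried on that aromatic carbon in place of either methylpyrazole.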